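From 3-methylphenyl to 2-fluorophenyl in an antiproliferative series

This account rests on a few compounds, and the source may have more. Where it says the series, first, only, none or still open, it means among the compounds named here.

In a functional assay on OVCAR-3 cells (Homo sapiens) for antiproliferative activity, read by MTT assay, with a stated time of 24 h (a higher number here means a weaker inhibitor, a lower number a stronger inhibitor), compound 1 `O=C(NNc1cccc(Cl)c1)c1ccc(NS(=O)(=O)c2cnc(O)nc2O)cc1` gives 8410 nM. Compound 2 `Cc1cccc(NNC(=O)c2ccccc2NS(=O)(=O)c2cnc(O)nc2O)c1` gives > 20000 nM, which is a limit of the assay and not a number. Compound 3 `O=C(NNc1ccccc1F)c1ccccc1NS(=O)(=O)c1cnc(O)nc1O` differs from compound 2 in one place, with 2-fluorophenyl in place of 3-methylphenyl on an amine nitrogen. Among the compounds with values here, no measured step shows what such a swap does in this assay. The estimated step of an at least 1.1-fold lower number from compound 2 to compound 3 (0.07 log units; that floor lies within the scatter) is therefore expected to stay within the usual scatter, in neither direction. Compound 3 is expected at 17000 nM, with an estimated range of 7000 nM to 35000 nM.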

Compound 3, half-maximal inhibitory concentration: 9570 nM
For compound 3 the middle estimate is 1.8-fold (0.25 log units) above the measured one; the measured number falls inside the stated range.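

In this assay, 2-fluorophenyl in place of 3-methylphenyl on an amine nitrogen gives an at least 2.0-fold lower number from compound 2 to compound 3 (0.32 log units; beyond the scatter) and shows that the group on this nitrogen can change the read-out. Compound 2 gives > 20000 nM which is a limit of the assay and not a number. The size of the step can therefore be stated only as a floor: the limit of > 20000 nM in this assay, at which 1 of the 3 values shown sits.

As far as these compounds go, it remains open whether the fluorine itself or the place of the group on the ring matters. A plain phenyl, 3-fluorophenyl or 2-methylphenyl on the same nitrogen would separate these two readings.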